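Trifluoromethyl for methyl on a chloro-substituted ring

The source may report more compounds than this note shows. Statements on the series, on what has been measured and on what is new or still open speak of the compounds shown alone.

Compound 1 `CC/C(=C(/c1ccc(/C=C/C(=O)O)cc1)c1cc2ccccc2[nH]1)c1cccc(C)c1` gives 140 nM in a functional assay on MCF7 cells (Homo sapiens) for inhibition; on this read-out higher numbers stand for weaker inhibition and lower numbers for stronger inhibition. Compound 2 `CC/C(=C(/c1ccc(/C=C/C(=O)O)cc1)c1cc2ccccc2[nH]1)c1cccc(C(F)(F)F)c1` differs from it by one change, (trifluoromethyl in place of methyl on an aromatic carbon), and in this assay compound 2 gives 325 nM, so that a 2.3-fold higher number from compound 1 to compound 2 (0.37 log units; beyond the scatter). Compound 3 `CC/C(=C(/c1ccc(/C=C/C(=O)O)cc1)c1cc2ccccc2[nH]1)c1ccc(Cl)c(C)c1` differs from compound 1 by chloro in place of hydrogen on an aromatic carbon; in this assay compound 3 gives 840 nM, and a 6.0-fold higher number from compound 1 to compound 3 (0.78 log units; beyond the scatter). Between the two substituted rings, a 2.6-fold higher number from compound 2 to compound 3 (0.41 log units; beyond the scatter).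

Compound 4 `CC/C(=C(/c1ccc(/C=C/C(=O)O)cc1)c1cc2ccccc2[nH]1)c1ccc(Cl)c(C(F)(F)F)c1` has not yet been measured. It differs from compound 3 by trifluoromethyl in place of methyl on an aromatic carbon. For the measured compounds named here, this is the same kind of change as the one from compound 1 to compound 2, but not the same: in compound 4 the entering group sits ortho to a chloro group and meta to a large group, whereas in compound 2 it sits only meta to a large group.

Going by the values given here, compound 4 is expected to show a step of about a 2.3-fold higher number from compound 3 to compound 4 (0.35 log units; beyond the scatter), because a 2.3-fold higher number from compound 1 to compound 2 (0.37 log units; beyond the scatter) is the only measured instance of this change and is taken as roughly the size to expect here. Compound 4 is therefore estimated at 1900 nM in this assay, with a range from 900 nM to 4500 nM.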

Compound 4, half-maximal inhibitory concentration: 2200 nM
Compound 4: the middle estimate sits 1.2-fold (0.06 log units) below what was measured; the range from low to high includes it.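

In this assay, trifluoromethyl in place of methyl gives a 2.6-fold higher number from compound 3 to compound 4 (0.42 log units; beyond the scatter), so the step keeps its size when it is carried from the ring without chloro to the ring with chloro: the same change on two cores in this assay, a 2.3-fold higher number (0.37 log units; beyond the scatter) from compound 1 to compound 2 and a 2.6-fold higher number (0.42 log units; beyond the scatter) from compound 3 to compound 4, 1.1-fold (0.05 log units) apart, within the scatter of two such steps. Chloro in place of hydrogen likewise holds its size on the trifluoromethyl ring, with a 6.8-fold higher number from compound 2 to compound 4 (0.83 log units; beyond the scatter), and the two changes together give a 16-fold higher number from compound 1 to compound 4 (1.20 log units; beyond the scatter), the largest step among these compounds: the same change on two cores in this assay, a 6.0-fold higher number (0.78 log units; beyond the scatter) from compound 1 to compound 3 and a 6.8-fold higher number (0.83 log units; beyond the scatter) from compound 2 to compound 4, 1.1-fold (0.05 log units) apart, within the scatter of two such steps. This agreement rests on only four compounds that share one core and were compared in one assay, so it shows that the two changes act independently here, but not that they would do so on another core, nor why either change raises the number.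

The compounds shown leave open whether the same steps would hold with fluoro or bromo in place of the chloro, or with methoxy or ethyl in place of the methyl. They also leave open whether the steps would survive replacing the carboxylic acid with an amide.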